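Swapping a halogen on the benzyl group of compound 2

The source may report more compounds than this note shows. Statements on the series, on what has been measured and on what is new or still open speak of the compounds shown alone.

Measured so far:
- Compound 1, `Cc1ccccc1Nc1nc(SCc2cn(Cc3ccc(Cl)cc3)nn2)nc(-c2ccccc2)c1C#N`, in a functional assay on ECa-109 cells (Homo sapiens) for inhibition, read by MTT assay, with a stated time of 72 h (a higher number here means a weaker inhibitor, a lower number a stronger inhibitor), compound 1 gives > 64000 nM, which is a limit of the assay and not a number.
- Compound 2, `Cc1ccc(Nc2nc(SCc3cn(Cc4ccc(Cl)cc4)nn3)nc(-c3ccccc3)c2C#N)cc1`, in this assay compound 2 gives > 64000 nM, again a limit of the assay and not a number.

Among the compounds with values here, compound 2 therefore stands at the top edge of what this assay can report; the same is true of compound 1, and the only step so far, a step that the two limits leave unreadable from compound 1 to compound 2, cannot be read, as both of its ends sit at the limit of > 64000 nM in this assay, at which 2 of the 2 values shown sit.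

The new compound, compound 3, `Cc1ccc(Nc2nc(SCc3cn(Cc4ccc(F)cc4)nn3)nc(-c3ccccc3)c2C#N)cc1`, differs from compound 2 in one place: fluoro in place of chloro on an aromatic carbon. Within the data shown here, no measured step touches this change, and the one step that exists gives no size to anchor it. On these data alone, both measured compounds sit at the limit, so the starting point itself is unknown beyond that limit. The step of a number no higher from compound 2 to compound 3 (the limit leaves the size open) is expected to be no change that the assay could reveal. Compound 3 is thus expected to give 64000 nM in this assay, with a range from 30000 nM to 200000 nM, and most likely another limit rather than a number.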

Compound 3, half-maximal inhibitory concentration: 42700 nM
For compound 3 the middle estimate is 1.5-fold (0.18 log units) above the measured one; low and high end bracket the measured number.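

Within the data shown here, compound 3 is the first compound here to give a true number in this assay, at 42700 nM, so this position now has one value that lies inside the range the assay can report. Placing fluoro in place of chloro on an aromatic carbon, para to a large group, goes with an at least 1.4-fold lower number from compound 2 to compound 3 (0.17 log units; that floor lies within the scatter), and because only that floor is known and it lies within the usual scatter, the result alone does not establish a real gain from this change. The real size of the step could be larger, but it stays unknown because one of its two ends is a limit of the assay and not a number: the limit of > 64000 nM in this assay, at which 2 of the 3 values shown sit.

On these data alone, the step between compound 1 and compound 2 still cannot be read, so it remains open whether 2-methylphenyl and 4-methylphenyl differ at all, with either the 4-chlorobenzyl or the 4-fluorobenzyl group. Also open, as far as these compounds go, is how other groups on this aromatic carbon, such as bromo, methoxy or an amine, would compare with fluoro, and whether removing the halogen altogether would keep a readable number.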